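Carbamoyl-Triazole Returns in Place of Methylimidazole

The compounds below may be only part of what the source reports. "The series", "measured", "known", "first", "only" and "open" are said of these compounds alone.

Measured so far:
compound 1 `CCO/C(O)=C1\C(COCCn2cc(C(N)=O)nn2)=NC(C)=C(C(=O)OC)C1c1ccccc1Cl` gives 20 nM in a functional assay (aorta) with Rattus norvegicus as the target; a higher number here means a weaker inhibitor, a lower number a stronger inhibitor
compound 2 `CCO/C(O)=C1\C(COCCn2ccnc2C)=NC(C)=C(C(=O)OC)C1c1ccccc1Cl` gives 2.51 nM in this assay

Compound 2 stands lowest of the two numbers in this assay; its nearest neighbour is compound 1, reached by an 8.0-fold lower number from compound 1 to compound 2 (0.90 log units; beyond the scatter). Compound 3 `CCO/C(O)=C1\C(COCCn2nncc2C(N)=O)=NC(C)=C(C(=O)OC)C1c1ccccc1Cl` has not yet been measured. It differs from compound 2 in one place: 5-carbamoyl-1H-1,2,3-triazol-1-yl in place of 2-methyl-1H-imidazol-1-yl on a saturated chain carbon, two bonds along the chain from an oxygen on a saturated carbon. Going by the values given here, the one measured step that bears on this change is the one from compound 1 to compound 2, where a 4-carbamoyl-1H-1,2,3-triazol-1-yl gave way to the 2-methyl-1H-imidazol-1-yl and the number fell by an 8.0-fold lower number from compound 1 to compound 2 (0.90 log units; beyond the scatter). Compound 3 reverses the sense of that exchange, bringing a carbamoyl-bearing 1,2,3-triazole back, though as the 5-carbamoyl-1H-1,2,3-triazol-1-yl rather than the 4-carbamoyl form of compound 1. Compound 3 is therefore expected to show a higher number than compound 2, by about a 6.4-fold higher number from compound 2 to compound 3 (0.80 log units; beyond the scatter), in this assay. Compound 3 is estimated at 16 nM, within a range from 5 nM to 50 nM.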

Compound 3, half-maximal inhibitory concentration: 100 nM
Estimate against measurement, compound 3: 6.3-fold (0.80 log units) below; measured number above the stated range.
By their numbers in this assay, from the lowest: compound 2; then compound 1; then compound 3.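

In this assay, the place of the carbamoyl group on the triazole proves to matter at this position: the 5-carbamoyl-1H-1,2,3-triazol-1-yl in place of the 4-carbamoyl-1H-1,2,3-triazol-1-yl gives a 5.0-fold higher number from compound 1 to compound 3 (0.70 log units; beyond the scatter), so the two isomers cannot be read as one group. Measured against the 2-methyl-1H-imidazol-1-yl, the 5-carbamoyl group gives a 40-fold higher number from compound 2 to compound 3 (1.60 log units; beyond the scatter), a larger step than the earlier one between the 4-carbamoyl group and the same imidazole, an 8.0-fold lower number from compound 1 to compound 2 (0.90 log units; beyond the scatter). No measurement is at hand that explains the difference between the two isomers.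

The compounds shown leave open how an unsubstituted imidazol-1-yl or an unsubstituted 1H-1,2,3-triazol-1-yl would compare at this place. They also leave open whether a carboxylic acid or a methyl group on the triazole, in place of the carbamoyl, would depend on its place in the same way.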